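Sulfonyl in place of carbonyl on the aromatic-ring nitrogen

The source may report more compounds than this note shows. Statements on the series, on what has been measured and on what is new or still open speak of the compounds shown alone.

Compound 3 `O=C(Nc1ncc(C(Oc2ccc3cc(Br)ccc3c2)c2ccc(Cl)cc2)s1)c1ccc(F)cc1Br` is one of three measured analogues on a shared core. In an ADME assay on HepG2 2.2.15 cells (Homo sapiens) for cytotoxicity (on this read-out lower numbers stand for higher toxicity in this test and higher numbers for lower toxicity in this test), compound 3 gives only a limit, > 50000 nM. Compound 1 `CCCCCC(=O)Nc1ncc(C(Oc2ccc3cc(Br)ccc3c2)c2ccc(Cl)cc2)s1` likewise gives only a limit, > 50000 nM. Compound 2 `CCN(CC)C(=O)Nc1ncc(C(Oc2ccc3cc(Br)ccc3c2)c2ccc(Cl)cc2)s1` is recorded as "not toxic" (no number reported), without a number. Among the measured compounds shown here, the single step between measured compounds, a step that the two limits leave unreadable from compound 1 to compound 3, cannot be read because both ends sit at the limit of > 50000 nM in this assay, at which 2 of the 3 values shown sit. Compound 4 `Cc1ccc(C)c(S(=O)(=O)Nc2ncc(C(Oc3ccc4cc(Br)ccc4c3)c3ccc(Cl)cc3)s2)c1` differs from compound 3 by (2,5-dimethylphenyl)sulfonyl in place of (2-bromo-4-fluorophenyl)carbonyl on a nitrogen on an aromatic ring. For the measured compounds named here, no measured step bears on this change, so the expectation rests only on compound 3 standing at the limit. Compound 4 is expected to give 50000 nM, between 20000 nM and 100000 nM. The step expected from this, a number no higher from compound 3 to compound 4 (the limit leaves the size open), is none beyond the scatter.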

Compound 4, half-maximal cytotoxic concentration: > 50000 nM
Compound 4: only a limit was reported; the forecaster's own chance of this, stated with the estimate: 80%; the middle value lies on the limit itself.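

In this assay compound 4 gives > 50000 nM, a limit and not a number. No step among compound 1, compound 3 and compound 4 can be read, as all three rest on one limit: the limit of > 50000 nM in this assay, at which 3 of the 4 values shown sit.

Going by these compounds, how far the sulfonyl of compound 4 and the carbonyl of compound 3 differ in this assay stays open.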